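Compound 2 to Compound 3: One Small Change on the Amide

The source may hold more compounds than are shown below. What is called first, only, known or untested is meant among the compounds shown, and "the series" means these compounds.

Compound 2 `C/C=C/C(=O)Nc1cccc(Oc2nc(Nc3ccc(OC)cc3)nc3c2CSCC3)c1` was tested on healthy-cell toxicity grounds in an ADME assay on L02 cells (Homo sapiens) for cytotoxicity, read by MTT assay, with a stated time of 72 h; a lower number here means a stronger inhibitor, a higher number a weaker inhibitor. There compound 2 gives > 50000 nM, which is a limit of the assay and not a number.

Compound 3 `COc1ccc(Nc2nc3c(c(Oc4cccc(NC(=O)C=C(C)C)c4)n2)CSCC3)cc1` differs from compound 2 in one place: on a carbonyl carbon, 2-methylprop-1-en-1-yl stands in place of prop-1-en-1-yl (2-methylprop-1-en-1-yl in place of prop-1-en-1-yl on a carbonyl carbon). Within the data shown here, no measured pair of compounds shows directly what this change does.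

The nearest clue is compound 1 `CC(C)=CC(=O)Nc1cccc(Oc2nc(Nc3ccn(C)n3)nc3c2CSCC3)c1`, which already carries the 2-methylprop-1-en-1-yl group. Compound 1 gives > 50000 nM, again a limit, so no step beyond the scatter is expected in this assay.

The estimated change is a number no higher from compound 2 to compound 3 (the limit leaves the size open). The assay may well report only a limit once more. For compound 3 the expected value is 50000 nM, with an estimated range from 20000 nM to 100000 nM.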

Compound 3, half-maximal inhibitory concentration: > 50000 nM
Compound 3 ended at the assay's limit (the forecaster's own chance of this, stated with the estimate: 85%); the middle value sits exactly at the limit.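

No step can be read from compound 2 to compound 3 or from compound 1 to compound 3, because all three compounds end at the same limit, which is not a number: the limit of > 50000 nM in this assay, at which 3 of the 3 values shown sit. The compounds shown leave open whether either change, 2-methylprop-1-en-1-yl for prop-1-en-1-yl or 4-methoxyphenyl for 1-methyl-1H-pyrazol-3-yl, alters the true value.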